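This account rests on a few compounds, and the source may have more. Where it says the series, first, only, none or still open, it means among the compounds named here.

Compound 1 `COc1ccc(-c2cnc(NC(=O)c3cccc(O)c3)n2C)cc1` with > 100000 nM as its reading
Compound 2 `COc1ccc(-c2cnc(NC(=O)c3ccn[nH]3)n2C)cc1` with > 100000 nM as its reading

In a toxicity assay on THP-1 cells (Homo sapiens) for inhibition (a lower number here means that less compound is tolerated, a higher number that more compound is tolerated), compound 2 stands at > 100000 nM and this is a limit of the assay, not a number. Compound 1 gives > 100000 nM in this assay and this too is a limit. Both readings therefore sit together, as the limit of > 100000 nM in this assay, at which 2 of the 2 values shown sit, shows, and no exact position can be given for either compound.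

The next compound is compound 3 `COc1ccc(-c2cnc(NC(=O)c3ccccc3OC)n2C)cc1` and the change is 2-methoxyphenyl in place of 1H-pyrazol-5-yl on a carbonyl carbon which puts 2-methoxyphenyl in place of 1H-pyrazol-5-yl on a carbonyl carbon. Among the measured compounds shown here, only one measured step bears on this swap, a step that the two limits leave unreadable from compound 1 to compound 2 and it has no readable size to carry forward. It does show that two different groups on that carbonyl carbon, 3-hydroxyphenyl and 1H-pyrazol-5-yl, both gave a limit rather than a number. With only these two compounds, this is thin evidence, but no clear fall in this assay is expected. The expected step is a number no higher from compound 2 to compound 3 (the limit leaves the size open) and it is not expected to exceed the usual scatter. For compound 3 the estimated value is about 100000 nM within an estimated range of 40000 nM to 200000 nM and a reading at the limit is the likeliest outcome.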

Compound 3, half-maximal cytotoxic concentration: > 100000 nM
Compound 3: no number, only a limit (the forecaster's own chance of this, stated with the estimate: 75%); the middle value sits exactly at the limit.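

Compound 1, compound 2 and compound 3 each give only a limit and not a number, so no step among them can be read in this assay: the limit of > 100000 nM in this assay, at which 3 of the 3 values shown sit.

The compounds shown leave open how much of each one the cells tolerate, and whether any group on that carbonyl carbon would give a measurable number.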